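The compounds below may be only part of what the source reports. "The series", "measured", "known", "first", "only" and "open" are said of these compounds alone.

Working notes on the series, read in a functional assay on PC-3 cells (Homo sapiens) for inhibition, read by sulforhodamine B assay; a higher number here means a weaker inhibitor of growth, a lower number a stronger inhibitor of growth. Compound 1 (`c1ccc(-c2ccc(-c3ccc(-c4nc5ccccc5[nH]4)cc3)cc2)cc1`) gives 41200 nM, compound 2 (`Clc1cccc(-c2ccc(-c3ccc(-c4nc5ccccc5[nH]4)cc3)cc2)c1`) gives 33700 nM, and compound 3 (`COc1ccc(-c2ccc(-c3ccc(-c4nc5ccccc5[nH]4)cc3)cc2)cc1OC`) gives 47100 nM. Compound 1 stands level with both of the others, and these numbers support no order among the three. Chloro in place of hydrogen gives a 1.2-fold lower number from compound 1 to compound 2 (0.09 log units; within the scatter). Swapping phenyl for 3,4-dimethoxyphenyl gives a 1.1-fold higher number from compound 1 to compound 3 (0.06 log units; within the scatter), and the comparison of the two substituted compounds gives a 1.4-fold higher number from compound 2 to compound 3 (0.15 log units; within the scatter).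

Compound 4 (`Oc1cccc2[nH]c(-c3ccc(-c4ccc(-c5ccccc5)cc4)cc3)nc12`) has not yet been measured. It differs from compound 1 by hydroxy in place of hydrogen on an aromatic carbon, which is hydroxy in place of hydrogen on an aromatic carbon, on a six-membered aromatic ring of carbon only that is part of a fused or bridged system of two rings. Among the compounds with values here, none of the measured steps introduces a hydroxy or touches that fused system, so they bear on this change only indirectly. Within the data shown here, they show that three different substitutions elsewhere leave the numbers within the scatter, and no direct precedent exists for this one. No step beyond the scatter is therefore expected in this assay, though the range is kept wide. The expected step is a 1.4-fold lower number from compound 1 to compound 4 (0.14 log units; within the scatter). For compound 4 the estimated value is 30000 nM, with an expected range from 10000 nM to 60000 nM.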

Compound 4, concentration for 50% growth inhibition: 1240 nM
Compound 4: the middle estimate sits 24-fold (1.38 log units) above what was measured; measured number below the stated range.
By their numbers in this assay, from the lowest: compound 4; then compounds 2, 1 and 3 (each within the scatter of the next).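

In this assay, within the data shown here, hydroxy in place of hydrogen gives a 33-fold lower number from compound 1 to compound 4 (1.52 log units; beyond the scatter) and this large step is beyond the scatter, the first such step. The earlier changes, chloro in compound 2 and 3,4-dimethoxyphenyl in compound 3, left the numbers within the scatter of compound 1 and did not touch the fused system, so they gave no sign that the core of compound 1 could respond this strongly. Compound 4 shows that one added heavy atom, on an aromatic carbon of the six-membered aromatic ring of carbon only, ortho to a fused ring and meta to a fused ring, is enough to separate a compound from the rest of the series, but no measurement at hand bears on why the step is so large.

The compounds shown leave open whether the hydroxy itself matters at this carbon or whether a methoxy, an amine or a fluorine there would give a step of similar size. They also leave open whether hydroxy on the other carbons of this ring would do the same, and whether the chloro of compound 2 would add anything when combined with the hydroxy of compound 4.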